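The source may report more compounds than this note shows. Statements on the series, on what has been measured and on what is new or still open speak of the compounds shown alone.

Measured compounds:
Compound 1, `N=C(N)NCCC[C@H](NC(=O)CN(c1nc(Cl)nc2[nH]cnc12)C1CC1)C(=O)O`, gives 17% in a functional assay on the whole organism (Tail, strain ICR) with Mus musculus as the target, in the tail flick test, with a stated time of 120 min, at a dose of 25 umol/kg by the oral route; a higher number here means a stronger effect of the compound at the dose given, a lower number a weaker effect.
Compound 2, `N=C(N)NCCC[C@H](NC(=O)CN(c1nc(Cl)nc2[nH]cnc12)C1CC1)C(=O)OCc1ccccc1`, gives 10.2% in this assay.
Compound 3, `O=C(CN(c1ncnc2c1ncn2C1CCCCO1)C1CC1)N[C@@H](CC(=O)OCc1ccccc1)C(=O)OCc1ccccc1`, gives 7.82% in this assay.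

Compound 2 stands second of the three numbers in this assay. Its nearest neighbour is compound 3 and its furthest is compound 1, but both gaps lie within the scatter, so the three compounds cannot be ranked against one another. Within the data shown here, the only measured step between neighbouring structures, a number 6.8 percentage points lower from compound 1 to compound 2 (within the scatter), concerns the ester end of the molecule and is itself within the scatter.

Compound 4, `CC(C)C[C@H](NC(=O)CN(c1nc(Cl)nc2[nH]cnc12)C1CC1)C(=O)OCc1ccccc1`, differs from compound 2 in a different place: a group of 3 heavy atoms (3 carbon; no ring) in place of a group of 6 heavy atoms (3 carbon, 3 nitrogen; no ring), on a saturated chain carbon, two bonds along the chain from an amide-type nitrogen and a carbonyl carbon. No measured step touches this part of the structure, so nothing in the data points to a shift in either direction, and the flat picture across compounds 1 to 3 gives no reason to expect a step beyond the scatter in this assay.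

Compound 4 is therefore estimated to give 10%, with a range from 2% to 20%. This corresponds to an expected step of a number 0.2 percentage points lower from compound 2 to compound 4 (within the scatter).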

Compound 4, a percentage reported as activity, at one dose (the size of the read-out at that dose, not a potency): 8.58%
The estimate for compound 4 lay 1.4 percentage points above the measured number; the range from low to high includes it.
By their numbers in this assay, from the lowest: compounds 3, 4, 2 and 1 (each within the scatter of the next).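

This position had not been touched by any earlier step, and here the group of 6 heavy atoms, with its 3 hydrogen-bond donors, gives way to isopropyl, with 0 hydrogen-bond donors. In this assay this exchange gives a number 1.6 percentage points lower from compound 2 to compound 4 (within the scatter), so losing all the nitrogen atoms of that group leaves no change that can be told from the scatter. Nothing available offers a cause for this result.

Still open, going by these compounds, is how an amine, a carboxylic acid or a longer chain on this saturated chain carbon would read, and whether any group there can move the number beyond the scatter. Among these compounds, the exchange is also seen only with the benzyl ester, so its effect alongside the free acid of compound 1 remains unknown.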